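This account rests on a few compounds, and the source may have more. Where it says the series, first, only, none or still open, it means among the compounds named here.

In a functional assay on cells (Cancer cell lines, Homo sapiens) for cytotoxicity, with a stated time of 48 h (on this read-out lower numbers stand for stronger inhibition of growth and higher numbers for weaker inhibition of growth), compound 1 `COc1c(/C=C2/C(=O)Nc3ccc(Cl)cc32)c2ccccc2n1-c1ccccc1` gives 5250 nM, the highest of the three numbers in hand. Compound 2 `COc1cc2c(/C=C3/C(=O)Nc4ccc(O)cc43)c(Cl)n(Cc3cc(OC)c(OC)c(OC)c3)c2cc1C` gives 2040 nM and compound 3 `COc1cc2c(/C=C3/C(=O)Nc4ccc(Cl)cc43)c(Cl)n(Cc3cc(OC)c(OC)c(OC)c3)c2cc1C` gives 2340 nM; both gaps to compound 1 lie beyond the scatter. Going by the values given here, the only single-change step measured, a 1.1-fold higher number from compound 2 to compound 3 (0.06 log units; within the scatter), alters the same position at which compound 1 carries chloro and stays within the scatter. Compound 4 `COc1c(/C=C2/C(=O)Nc3ccccc32)c2ccccc2n1-c1ccccc1` differs from compound 1 by hydrogen in place of chloro on an aromatic carbon. The step from compound 2 to compound 3 bears on this only loosely: it trades chloro for hydroxy rather than for hydrogen, yet it gives no sign that this position moves the read-out much. The expected step of a 1.1-fold higher number from compound 1 to compound 4 (0.06 log units; within the scatter) is therefore small, probably within the scatter. Compound 4 is estimated at 6000 nM, ranging from 2500 nM to 15000 nM.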

Compound 4, concentration for 50% growth inhibition: 2190 nM
Compound 4: the middle estimate sits 2.7-fold (0.44 log units) above what was measured, outside the stated range (below it).
By their numbers in this assay, from the lowest: compounds 2, 4 and 3 (each within the scatter of the next); then compound 1.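

In this assay, hydrogen in place of chloro on this aromatic carbon gives a 2.4-fold lower number from compound 1 to compound 4 (0.38 log units; beyond the scatter), so on the core of compound 1 this position does move the read-out, and chloro is not needed for growth inhibition there. The earlier change, a 1.1-fold higher number from compound 2 to compound 3 (0.06 log units; within the scatter), stayed within the scatter, but it involved hydroxy rather than hydrogen and a different core. Nothing at hand explains the new step.

Open, going by these compounds, is how fluoro, an amine or a carboxylic acid on this carbon would read. Also open, on these data alone, is whether hydrogen in place of chloro would give a similar step on the core of compound 3.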